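This account rests on a few compounds, and the source may have more. Where it says the series, first, only, none or still open, it means among the compounds named here.

The measured compounds are compound 1 `C[C@@H](O)[C@H](NC(=O)CN(c1nc(Cl)nc2[nH]cnc12)C1CC1)C(=O)O`, compound 2 `C[C@H](NC(=O)CN(c1ncnc2c1ncn2C1CCCCO1)C1CC1)C(=O)OCc1ccccc1` and compound 3 `NC(=O)CC[C@H](NC(=O)CN(c1nc(Cl)nc2[nH]cnc12)C1CC1)C(=O)O`. In a functional assay on the whole organism (Tail, strain ICR) with Mus musculus as the target, in the tail flick test, with a stated time of 120 min, at a dose of 25 umol/kg by the oral route (a higher number here means a stronger effect of the compound at the dose given, a lower number a weaker effect), compound 1 gives 37.6%, compound 2 gives 25.3% and compound 3 gives 17.8%.

Compound 2 stands second of the three numbers: its gap to compound 3 lies within the scatter, while compound 1 sits beyond the scatter above it. Compound 4 `C[C@@H](O)[C@H](NC(=O)CN(c1ncnc2c1ncn2C1CCCCO1)C1CC1)C(=O)OCc1ccccc1` differs from compound 2 by 1-hydroxyethyl in place of methyl on a saturated chain carbon bound to an amide-type nitrogen and a carbonyl carbon. For the measured compounds named here, no measured step carries this same change. Going by the values given here, the only measured step, a number 19.8 percentage points lower from compound 1 to compound 3 (beyond the scatter), exchanges a different group at the same place, and there the 1-hydroxyethyl compound was the stronger one. On that slender ground a small rise is expected, a number 7.7 percentage points higher from compound 2 to compound 4 (within the scatter). Compound 4 is therefore estimated at 33%, with a range from 18% to 48%.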

Compound 4, a percentage reported as activity, at one dose (the size of the read-out at that dose, not a potency): 10.9%
For compound 4 the middle estimate is 22.1 percentage points above the measured one, outside the stated range (below it).
By their numbers in this assay, from the lowest: compounds 4, 3 and 2 (each within the scatter of the next, the first and the last beyond it); then compound 1.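

In this assay, 1-hydroxyethyl in place of methyl on a saturated chain carbon bound to an amide-type nitrogen and a carbonyl carbon gives a number 14.4 percentage points lower from compound 2 to compound 4 (beyond the scatter) on this shared core. For the compounds shown here, this is the first direct reading of 1-hydroxyethyl against methyl at this place, and here the larger group carries the lower number. The earlier step set it only against 2-carbamoylethyl, on another core, and does not predict this result. Nothing given here accounts for the drop.

As far as these compounds go, whether the same change gives a similar step on the core of compound 1 remains open. So does how a longer chain or an amine would read at this place.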